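The source may hold more compounds than are shown below. What is called first, only, known or untested is meant among the compounds shown, and "the series" means these compounds.

Measured in an assay on isolated protein for inhibition of serine/threonine-protein kinase 10 (Homo sapiens), read by thermal shift assay, tested at 10 uM; on this read-out lower numbers stand for weaker stabilisation of the target and higher numbers for stronger stabilisation of the target against heat:
compound 1 `CC(C)(C)c1cc(NC(=O)Nc2cc(C(F)(F)F)cc(C(F)(F)F)c2)n(-c2ccccc2)n1` gives -0.5 degrees C
compound 2 `Cc1cc(C)cc(NC(=O)Nc2cc(C(C)(C)C)nn2-c2ccccc2)c1` gives -0.3 degrees C
compound 3 `Cc1ccc(S(=O)(=O)NC(=O)Nc2cc(C(C)(C)C)nn2-c2ccccc2)cc1` gives -0.9 degrees C

Compound 1 stands second highest of the three numbers in this assay. Its nearest neighbour is compound 2, whose number lies within the scatter of that of compound 1; the furthest is compound 3, and that gap too lies within the scatter. The three numbers are thus not to be told apart. Among the measured compounds shown here, the measured compounds differ from one another in more than one place, so no single step between them can be read off.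

Compound 4 `CC(C)(C)c1cc(NC(=O)Nc2cc(C(F)(F)F)cc(C(F)(F)F)c2)n(C(C)(C)C)n1` differs from compound 1 in one place: tert-butyl in place of phenyl on an aromatic nitrogen. The three measured compounds all sit within the scatter of each other in this assay; no step beyond the scatter is expected here either, in either direction. Compound 4 is therefore estimated at -0.5 degrees C, with a range from -1.5 degrees C to 0.5 degrees C. The expected step is no change at the digits printed from compound 1 to compound 4 (within the scatter), none beyond the scatter.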

Compound 4, shift of the target's melting temperature: -0.7 degrees C
The estimate for compound 4 lay 0.20 degrees C above the measured number; measured number inside the range.
By their numbers in this assay, from the lowest: compounds 3, 4, 1 and 2 (each within the scatter of the next).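

Among the compounds shown here, putting tert-butyl in place of phenyl on an aromatic nitrogen gives a number 0.20 degrees C lower from compound 1 to compound 4 (within the scatter) in this assay, the first single-place step that can be read. With this step within the scatter, the read-out does not tell apart a six-membered aromatic ring of carbon only and a group with no ring at this position, at least in the setting of compound 1 and compound 4. No supporting measurement accounts for this result.

From the compounds shown here alone, whether a carboxylic acid or an amine on a longer chain at this nitrogen would give a step beyond the scatter remains open. Also open, going by these compounds, is whether the same exchange would give a similar step with the other end of the molecule as it stands in compound 2 or compound 3.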